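Lipophilicity notes: trifluoromethyl to acetyl on the aryl ring

The compounds below may be only part of what the source reports. "The series", "measured", "known", "first", "only" and "open" are said of these compounds alone.

Measured so far:
compound 1 `CNc1nc(NCCCN(C)C)c2sc(-c3cccc(C#N)c3)cc2n1` — 2.9
compound 2 `CNc1nc(NCCCN(C)C)c2sc(-c3ccc(C(F)(F)F)cc3)cc2n1` — 4.1

In a physicochemical assay for lipophilicity, read by HPLC, at pH 7.4 (on this read-out higher numbers stand for higher lipophilicity and lower numbers for lower lipophilicity), compound 2 gives 4.1, the higher of the two numbers, and compound 1 gives 2.9; the gap between these two numbers is beyond the scatter. Compound 3 `CNc1nc(NCCCN(C)C)c2sc(-c3ccc(C(C)=O)cc3)cc2n1` has not been measured in this assay. It differs from compound 2 by acetyl in place of trifluoromethyl on an aromatic carbon. Among the compounds with values here, no measured pair shows this exact change, so its size is not known from the series. For compound 3 a step down of about a number 1.30 log units lower from compound 2 to compound 3 (beyond the scatter) is expected, taking the number toward the region where compound 1 gives 2.9. Compound 3 is therefore estimated at 2.8, with a range from 2.3 to 3.3.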

Compound 3, distribution coefficient: 2.9
Compound 3: middle estimate off by 0.10 log units, on the low side; the range from low to high includes it.
By their numbers in this assay, from the lowest: compounds 1 and 3 (each within the scatter of the next); then compound 2.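

Within the data shown here, on the aromatic carbon para to a large group, acetyl in place of trifluoromethyl gives a number 1.20 log units lower from compound 2 to compound 3 (beyond the scatter) in this assay and so puts a measured size on this exchange for the first time. 4-Acetylphenyl in place of 3-cyanophenyl gives no change at the digits printed from compound 1 to compound 3 (within the scatter) on the same read-out. No supporting measurement bears on the reason for either step.

Still open, going by these compounds, is where an amine or a carboxylic acid on the same aromatic carbon would fall in this assay relative to acetyl. The contributions of group identity and ring placement to the match between 4-acetylphenyl and 3-cyanophenyl also remain unseparated.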